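The source may hold more compounds than are shown below. What is called first, only, known or untested is meant among the compounds shown, and "the series" means these compounds.

In an ADME assay on cells for inhibition of anoctamin-2 (Homo sapiens), read by fluorescence, with a stated time of 20 min (on this read-out higher numbers stand for weaker inhibition and lower numbers for stronger inhibition), compound 1 `Cc1cc(Cl)ccc1OC(F)(F)C(=O)N/N=C/c1ccccc1OC(F)(F)F` gives > 100000 nM, which is a limit of the assay rather than a number. Compound 2 `Cc1cc(Cl)ccc1OCC(=O)N/N=C/c1ccccc1F` is reported in this assay only as "not active" (no number reported), without a number. Compound 3 `Cc1cc(Cl)ccc1OCC(=O)N/N=C/c1ccccn1` in this assay gives > 100000 nM, again a limit and not a number. Compound 3 therefore stands at the limit of > 100000 nM in this assay, at which 2 of the 3 values shown sit, where most of what has been measured sits. Compound 4 `Cc1cc(Cl)ccc1OCC(=O)N/N=C/c1ccco1` differs from compound 3 by furan-2-yl in place of pyridin-2-yl on a carbon with a double bond to nitrogen. Among the compounds with values here, no pair of measured compounds differing in one place is available, so nothing shows how such a change moves this read-out. The expected step of a number no higher from compound 3 to compound 4 (the limit leaves the size open) is none beyond the usual scatter. Compound 4 is thus expected to give about 100000 nM, with a range from 30000 nM to 300000 nM.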

Compound 4, half-maximal inhibitory concentration: "not active" (no number reported)
Compound 4: no number reported, and the estimate cannot be compared.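

No step can be read from compound 3 to compound 4: compound 4 is reported only as not active, without a number. The compounds shown leave open which change, if any, would give a measurable value in this assay.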